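The source may hold more compounds than are shown below. What is called first, only, known or untested is meant among the compounds shown, and "the series" means these compounds.

Measured compounds:
compound 1, `CCCCCCCCc1cn([C@@H]2O[C@@H]3COP(=O)(O)O[C@H]3[C@H]2O)c(=O)nc1N` — > 200 ug/mL
compound 2, `Cc1cn([C@@H]2O[C@@H]3COP(=O)(O)O[C@H]3[C@H]2O)c(=O)nc1N` — > 200 ug/mL

In a functional assay on L1210 cells (Mus musculus) for cytotoxicity (on this read-out lower numbers stand for stronger inhibition and higher numbers for weaker inhibition), compound 2 gives only a limit, > 200 ug/mL, and not a number. Compound 1 likewise stops at a limit, (the limit of > 200 ug/mL in this assay, at which 2 of the 2 values shown sit). Within the data shown here, the single measured step, a step that the two limits leave unreadable from compound 1 to compound 2, is therefore of unreadable size, since both of its ends are limits.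

Compound 3, `CCCCCCc1cn([C@@H]2O[C@@H]3COP(=O)(O)O[C@H]3[C@H]2O)c(=O)nc1N`, is not yet measured. It differs from compound 2 by pentyl in place of hydrogen on a saturated chain carbon bound to an aromatic carbon. Its chain lies between those of compound 1 and compound 2, and both of those gave only a limit in this assay, so no step beyond the scatter is expected, and a limit is again the most likely outcome. Compound 3 is expected to give about 300 ug/mL, with a range from 100 ug/mL to 1000 ug/mL. The step from compound 2 to compound 3 is accordingly estimated at a step that the limit leaves unreadable from compound 2 to compound 3.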

Compound 3, concentration for 50% inhibition: > 200 ug/mL
Compound 3: only a limit was reported; the forecaster's own chance of this, stated with the estimate: 85%; the middle value is on the limit's open side.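

In this assay, no step can be read among compound 1, compound 2 and compound 3, since each gives only a limit: the limit of > 200 ug/mL in this assay, at which 3 of the 3 values shown sit.

The compounds shown leave open how far these three differ in this assay, and whether any chain on the shared core gives a numeric value there.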